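The source may hold more compounds than are shown below. What is called first, only, known or untested is meant among the compounds shown, and "the series" means these compounds.

Measured so far:
- compound 1 `CCC(=O)N1CCN(S(=O)(=O)c2ccc(F)cc2)CC1`, giving 0.01 mg/kg
- compound 2 `CCCS(=O)(=O)N1CCN(C(=O)CC)CC1`, giving 1 mg/kg

Both numbers come from a functional assay on the whole organism with Mus musculus as the target; on this read-out higher numbers stand for an effect only at larger amounts of compound and lower numbers for an effect already at smaller amounts. Among the compounds with values here, compound 1 holds the lowest of the two numbers; the only other compound, compound 2, sits at a far higher number, and that gap lies well beyond the scatter of the assay. The two structures differ in more than one place, so nothing is concluded from that pair about any single change.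

The next compound, compound 3 `CC(=O)N1CCN(S(=O)(=O)c2ccc(F)cc2)CC1`, is still to be measured in this assay. It differs from compound 1 in one place only: hydrogen in place of methyl on a saturated chain carbon bound to a carbonyl carbon. The amide side of the shared core is shortened by one carbon while the sulfonyl side is left as in compound 1.

Within the data shown here, no measured step of this kind is available for the series, so the expectation rests on the small size of the change and on compound 1 at 0.01 mg/kg. The step that this estimate implies, a 2.0-fold higher number from compound 1 to compound 3 (0.30 log units; within the scatter), is expected to be small, within the scatter or only slightly beyond it, toward a somewhat higher number. Compound 3 is estimated at 0.02 mg/kg, with a range from 0.005 mg/kg to 0.1 mg/kg.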

Compound 3, minimum effective dose: 0.01 mg/kg
For compound 3 the middle estimate is 2.0-fold (0.30 log units) above the measured one; the range from low to high includes it.
By their numbers in this assay, from the lowest: compounds 1 and 3 (each within the scatter of the next); then compound 2.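

Within the data shown here, for hydrogen in place of methyl on a saturated chain carbon bound to a carbonyl carbon, the first single-place step reads no change at the digits printed from compound 1 to compound 3 (within the scatter) in this assay. With the sulfonyl side held as in compound 1, the methyl at the end of the propanoyl group can therefore be lost without a change beyond the scatter on this read-out. Nothing available points to a cause for this result.

The compounds shown leave open how this position responds to anything larger than propanoyl or to anything other than a plain alkyl chain, such as a butanoyl group, a cyclopropyl group, an amine or a carboxylic acid. Also open, from the compounds shown here alone, is whether the step from propanoyl to acetyl reads the same with the propylsulfonyl side of compound 2.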